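This account rests on a few compounds, and the source may have more. Where it says the series, first, only, none or still open, it means among the compounds named here.

Measured compounds:
Compound 1 `CCC1C(=O)N(C)c2cnc(-n3ccc4cc(C(N)=O)ccc43)nc2N1c1ccn(C)n1` — 39500 nM
Compound 2 `CCC1C(=O)N(C)c2cnc(-n3ccc4cc(C(=O)NC)ccc43)nc2N1c1ccn(C)n1` — 43100 nM
Compound 3 `CCC1C(=O)N(C)c2cnc(Nc3ccc(S(N)(=O)=O)cc3)nc2N1c1ccn(C)n1` — "not active" (no number reported)

In a functional assay on A549 cells (Homo sapiens) for antiproliferative activity, read by CCK-8 assay, with a stated time of 72 h (a lower number here means a stronger inhibitor of growth, a higher number a weaker inhibitor of growth), compound 2 gives the higher of the two numbers reported, yet its gap to compound 1, a 1.1-fold higher number from compound 1 to compound 2 (0.04 log units; within the scatter), lies within the scatter, so the two cannot be told apart. Compound 4 `CCC1C(=O)N(C)c2cnc(-n3ccc4cc(F)ccc43)nc2N1c1ccn(C)n1` has not yet been measured. It differs from compound 2 in one place: fluoro in place of methylcarbamoyl on an aromatic carbon. For the measured compounds named here, the only measured step, a 1.1-fold higher number from compound 1 to compound 2 (0.04 log units; within the scatter), touches the same group but only its nitrogen, and no measured pair removes the whole group, so it offers little guidance. Compound 3 was reported as not active, with no number. The expectation for compound 4 in this assay is therefore a step of about a 1.4-fold lower number from compound 2 to compound 4 (0.16 log units; within the scatter), within the scatter. Compound 4 is estimated at 30000 nM, with a range from 8000 nM to 120000 nM.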

Compound 4, concentration for 50% growth inhibition: "not active" (no number reported)
The entry for compound 4 holds no number; the estimate stays without a comparison.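

Compound 4 is reported as "not active" in this assay with no number, so no step from compound 2 to compound 4 can be read, and no supporting data offer an explanation. The compounds shown leave open how much growth inhibition changes when fluoro replaces methylcarbamoyl.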